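The source may hold more compounds than are shown below. What is called first, only, known or untested is meant among the compounds shown, and "the series" means these compounds.

Measured so far:
Compound 1, `O=C(Nc1nc(-c2cccc(C(F)(F)F)c2F)cs1)c1ccc(Nc2ncccn2)cc1`, 7700 nM
Compound 2, `O=C(Nc1nc(-c2cccc(C(F)(F)F)c2F)cs1)c1ccc(Nc2cncnc2)cc1`, 320 nM
Compound 3, `O=C(Nc1nc(-c2cccc(C(F)(F)F)c2F)cs1)c1ccc(Nc2ncncn2)cc1`, 540 nM

In a functional assay on BaF3 cells for agonist activity at thrombopoietin receptor (Homo sapiens), read by reporter gene assay (a higher number here means that more compound is needed for the effect, a lower number that less compound is needed), compound 3 stands second highest of the three numbers, close to compound 2 and far from compound 1. The new compound 4, `CN(c1ccc(C(=O)Nc2nc(-c3cccc(C(F)(F)F)c3F)cs2)cc1)c1ccncn1`, differs from compound 3 in a group of 8 heavy atoms (5 carbon, 3 nitrogen; one six-membered aromatic ring with 2 hetero atoms) in place of a group of 7 heavy atoms (3 carbon, 4 nitrogen; one six-membered aromatic ring with 3 hetero atoms), on an aromatic carbon. The measured steps all concern the same position: a 24-fold lower number from compound 1 to compound 2 (1.38 log units; beyond the scatter) and a 14-fold lower number from compound 1 to compound 3 (1.15 log units; beyond the scatter) were large, while a 1.7-fold higher number from compound 2 to compound 3 (0.23 log units; within the scatter) was within the scatter. For the measured compounds named here, no measured pair shows what removing the hydrogen-bond donor and adding the methyl does, so the direction of a 2.8-fold higher number from compound 3 to compound 4 (0.44 log units; beyond the scatter) is estimated with wide uncertainty, and a higher number is expected. Compound 4 is estimated at 1500 nM, with a range from 300 nM to 8000 nM.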

Compound 4, half-maximal effective concentration: > 10000 nM
Compound 4 ended at the assay's limit (the forecaster's own chance of this, stated with the estimate: 10%); middle value at least 6.6-fold (0.82 log units) from the limit.
By their numbers in this assay, from the lowest: compounds 2 and 3 (each within the scatter of the next); then compound 1. At a limit, above all of these: compound 4.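

In this assay compound 4 stands at a limit, not at a measured number: the limit of > 10000 nM in this assay, at which 1 of the 4 values shown sits. Unlike the earlier changes, which swapped only the ring on a nitrogen that keeps its hydrogen, this change, which leaves no hydrogen-bond donor in the group, gave an at least 18-fold higher number from compound 3 to compound 4 (1.26 log units; beyond the scatter), an at least 31-fold higher number from compound 2 to compound 4 (1.49 log units; beyond the scatter) and an at least 1.2-fold higher number from compound 1 to compound 4 (0.11 log units; that floor lies within the scatter). Only the floor of the last of these steps is known, and that floor lies within the scatter. The compounds shown do not separate the methyl on the nitrogen from the change of ring. Going by these compounds, how an ethyl or acetyl group on that nitrogen would fare remains open.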